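Methyl to hydrogen on the aromatic nitrogen of compound 1

The source may hold more compounds than are shown below. What is called first, only, known or untested is meant among the compounds shown, and "the series" means these compounds.

In a functional assay on PA-1 cells (Homo sapiens) for cytotoxicity, read by MTT assay, with stated times of 6 h and 48 h (a lower number here means a stronger inhibitor, a higher number a weaker inhibitor), compound 1 `COc1ccc(OC)c(C(=O)/C=C/c2cc(Br)c(Br)n2C)c1` reads 800 nM and compound 2 `Cn1c(/C=C/C(=O)c2ccc(Cl)cc2Cl)cc(Br)c1Br` stands at 1000 nM alongside it. Going by the values given here, these two numbers lie within the scatter of each other, so compound 1 sits level with the only other measured compound and no ranking can be drawn yet.

Compound 3 `COc1ccc(OC)c(C(=O)/C=C/c2cc(Br)c(Br)[nH]2)c1` keeps the core of compound 1 and differs in one place by hydrogen in place of methyl on an aromatic nitrogen. Among the compounds with values here, both measured compounds carry that methyl, so no measured pair shows what this change does in this assay so far. Within the data shown here, with no measured step to lean on, the expectation is modest: little movement, with at most a slight drift toward a weaker number and no firm direction. The estimated 1.3-fold higher number from compound 1 to compound 3 (0.10 log units; within the scatter) is small and is expected to stay within the scatter. For compound 3 the expected value is 1000 nM with an estimated range from 300 nM to 4000 nM for now.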

Compound 3, half-maximal inhibitory concentration: 420 nM
For compound 3 the middle estimate is 2.4-fold (0.38 log units) above the measured one; the measured number falls inside the stated range.
By their numbers in this assay, from the lowest: compounds 3, 1 and 2 (each within the scatter of the next, the first and the last beyond it).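

In this assay, going by these compounds alone, the first measured pair at this position shows that hydrogen in place of methyl on the aromatic nitrogen gives a 1.9-fold lower number from compound 1 to compound 3 (0.28 log units; within the scatter), so the two compounds cannot be told apart and the methyl is not needed to keep a reading of this size on the core of compound 1. Within the data shown here, the result therefore gives this change no firm direction, although the single pair gives no basis for carrying that reading over to other compounds. No measurement on hand bears on why the two compounds read as they do.

Still open, from the compounds shown here alone, is what larger groups on this aromatic nitrogen would do, such as an ethyl group, a longer chain, a benzyl group or an acetyl group, since methyl and hydrogen alone say little about how much room the position allows. Also open is whether hydrogen in place of methyl would read the same way on the core of compound 2, where only the methyl form is shown here, and a second pair of that kind would test whether the present reading holds beyond one core.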